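Sulfonyl substituent variation: notes toward compound 3

The compounds below may be only part of what the source reports. "The series", "measured", "known", "first", "only" and "open" are said of these compounds alone.

Measured so far:
Compound 1 `CCN1CCCC1CNC(=O)c1cc(NS(=O)(=O)N(C)C)ccc1OC` — > 50 mg/kg
Compound 2 `CCN1CCCC1CNC(=O)c1cc(NS(C)(=O)=O)ccc1OC` — > 50 mg/kg

In a functional assay on the whole organism for inhibition, with Mus musculus as the target (on this read-out higher numbers stand for an effect only at larger amounts of compound and lower numbers for an effect already at smaller amounts), compound 1 gives > 50 mg/kg, which is a limit of the assay and not a number. Compound 2 likewise gives > 50 mg/kg, again a limit. The step that the two limits leave unreadable from compound 1 to compound 2 therefore has no readable size. Compound 2 thus stands only at a limit; the limit of > 50 mg/kg in this assay, at which 2 of the 2 values shown sit, describes the whole of what this assay has shown for the pair.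

Compound 3 `CCN1CCCC1CNC(=O)c1cc(NS(=O)(=O)NC)ccc1OC` differs from compound 2 in one place: methylamino in place of methyl on a sulfonyl sulfur. Among the measured compounds shown here, the only measured step, from compound 1 to compound 2, bears on a change at the same sulfonyl sulfur but is unreadable, so no size can be carried over. With both measured values sitting at the limit, compound 3 is expected to land near that limit as well, at an estimated 80 mg/kg with a range of 30 mg/kg to 300 mg/kg. The corresponding expected step is a step that the limit leaves unreadable from compound 2 to compound 3.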

Compound 3, dose for half-maximal effect: > 50 mg/kg
Compound 3: only a limit was reported; the forecaster's own chance of this, stated with the estimate: 75%; the middle value lies beyond the limit too.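

No step can be read among compound 1, compound 2 and compound 3 in this assay, since all three results are limits and not numbers: the limit of > 50 mg/kg in this assay, at which 3 of the 3 values shown sit. Going by these compounds, whether dimethylamino, methyl and methylamino on the sulfonyl sulfur differ at all in this assay stays open.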